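From 4-fluorophenoxy to 2-methoxyphenoxy: working notes

This account rests on a few compounds, and the source may have more. Where it says the series, first, only, none or still open, it means among the compounds named here.

In a functional assay for inhibition, with Homo sapiens as the target (a lower number here means tighter binding, a higher number weaker binding), compound 3 (`CC(C)(Oc1ccc(F)cc1)C1OCC(C/C=C\CCC(=O)O)C(c2cccnc2)O1`) gives 120 nM, the highest of three numbers, against compound 2 (`Cc1ccc(C#N)c(OC(C)(C)C2OCC(C/C=C\CCC(=O)O)C(c3cccnc3)O2)c1`) at 15.9 nM and compound 1 (`CSc1ccc(OC(C)(C)C2OCC(C/C=C\CCC(=O)O)C(c3cccnc3)O2)c([N+](=O)[O-])c1`) at 4.47 nM. Compound 4 (`COc1ccccc1OC(C)(C)C1OCC(C/C=C\CCC(=O)O)C(c2cccnc2)O1`) has 2-methoxyphenyl in place of 4-fluorophenyl on an oxygen on a saturated carbon. Two measured steps arrive at 4-fluorophenyl, both beyond the scatter: a 7.5-fold higher number from compound 2 to compound 3 (0.88 log units; beyond the scatter), and the larger 27-fold higher number from compound 1 to compound 3 (1.43 log units; beyond the scatter). Neither contains 2-methoxyphenyl, so the support is indirect. The expected change is a move to a lower number, near the smaller step in size: a 3.4-fold lower number from compound 3 to compound 4 (0.54 log units; beyond the scatter). For compound 4 the estimated value is 35 nM, with an expected range of 12 nM to 100 nM.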

Compound 4, dissociation constant: 224 nM
Estimate against measurement, compound 4: 6.4-fold (0.81 log units) below, outside the stated range (above it).
By their numbers in this assay, from the lowest: compound 1; then compound 2; then compounds 3 and 4 (each within the scatter of the next).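

In this assay, 2-methoxyphenyl on this oxygen is not separated from 4-fluorophenyl (a 1.9-fold higher number from compound 3 to compound 4 (0.27 log units; within the scatter)). Both remain well apart from the groups in the two lower-number compounds (a 14-fold higher number from compound 2 to compound 4 (1.15 log units; beyond the scatter); a 50-fold higher number from compound 1 to compound 4 (1.70 log units; beyond the scatter)), so the methoxy group alone does not bring compound 4 toward them. No available evidence bears on the reason for this result.

Open is which part of the group in compound 1 carries its lower number, since no compound shown separates its substituents. Also open, as far as these compounds go, is how a phenyl bearing an amine or a carboxylic acid would read at this position.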